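3-Hydroxyphenyl to 3-methoxyphenyl: working notes

The source may report more compounds than this note shows. Statements on the series, on what has been measured and on what is new or still open speak of the compounds shown alone.

- compound 1 `CC1(C)[C@H]2CC[C@]1(C)N(Cc1cn(-c3ccccc3)nn1)C(=O)C2` gives 240 nM
- compound 2 `CC1(C)[C@H]2CC[C@]1(C)N(Cc1cn(-c3ccccc3O)nn1)C(=O)C2` gives 410 nM
- compound 3 `CC1(C)[C@H]2CC[C@]1(C)N(Cc1cn(-c3cccc(O)c3)nn1)C(=O)C2` gives 270 nM

All values come from a functional assay on SGC-7901 cells (Homo sapiens) for inhibition, read by MTT assay, with a stated time of 24 h (on this read-out higher numbers stand for weaker inhibition and lower numbers for stronger inhibition), and the three lie within the scatter of one another, so compound 3 is not separated from either neighbour. Compound 4 `COc1cccc(-n2cc(CN3C(=O)C[C@@H]4CC[C@@]3(C)C4(C)C)nn2)c1` differs from compound 3 by methyl in place of hydrogen on an oxygen on an aromatic ring. Going by the values given here, no measured step makes this change. The closest are the hydroxy steps a 1.1-fold higher number from compound 1 to compound 3 (0.05 log units; within the scatter) and a 1.7-fold higher number from compound 1 to compound 2 (0.23 log units; within the scatter) and the hydroxy shift a 1.5-fold lower number from compound 2 to compound 3 (0.18 log units; within the scatter) and none leaves the scatter. No step beyond the scatter is therefore expected, and the estimated step is a 1.1-fold higher number from compound 3 to compound 4 (0.03 log units; within the scatter) with its direction open. For compound 4 the estimate is 290 nM with an expected range from 130 nM to 620 nM in this read-out.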

Compound 4, half-maximal inhibitory concentration: 590 nM
For compound 4 the middle estimate is 2.0-fold (0.31 log units) below the measured one, and the stated range covers the measured number.
By their numbers in this assay, from the lowest: compounds 1, 3, 2 and 4 (each within the scatter of the next, the first and the last beyond it).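

Methyl in place of hydrogen on the oxygen gives the first step in this series to leave the scatter in this assay (a 2.2-fold higher number from compound 3 to compound 4 (0.34 log units; beyond the scatter)), and 3-methoxyphenyl is also separated from the unsubstituted phenyl (a 2.5-fold higher number from compound 1 to compound 4 (0.39 log units; beyond the scatter)). Thus the hydroxy group at this position can be replaced by methoxy only with a modest loss of inhibition. Compound 4 remains unseparated from the 2-hydroxyphenyl analogue (a 1.4-fold higher number from compound 2 to compound 4 (0.16 log units; within the scatter)). No available data account for the step.

On these data alone, whether 2-methoxyphenyl would read like 3-methoxyphenyl remains open. So does the outcome with an ethoxy or amino group at this position.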